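Swapping a fluorophenyl for a trifluoromethylphenyl on the core

The source may report more compounds than this note shows. Statements on the series, on what has been measured and on what is new or still open speak of the compounds shown alone.

Measured compounds:
- compound 1, `CN(Cc1ccc(OCCCN)cc1)c1nc2ccc(Oc3ccc(F)cc3)cc2s1`: 492000 nM
- compound 2, `CN(C)CCCOc1ccc(CN(C)c2nc3ccc(Oc4ccc(C#N)cc4)cc3s2)cc1`: 64000 nM
- compound 3, `N=C(N)NCCCOc1ccc(CNc2nc3ccc(Oc4ccc(C(F)(F)F)cc4)cc3s2)cc1`: 195000 nM

All three were tested in an assay on cells for inhibition of Voltage-dependent T-type calcium channel subunit alpha-1H (Homo sapiens), read by FLIPR and calcium flux, with stated times of 600 s and 300 s; on this read-out lower numbers stand for stronger inhibition and higher numbers for weaker inhibition. On these numbers compound 1 stands highest, so it is the weakest inhibitor of the three; compound 3 lies nearest to it and compound 2 furthest, both beyond the scatter. Compound 4, `CN(Cc1ccc(OCCCN)cc1)c1nc2ccc(Oc3cccc(C(F)(F)F)c3)cc2s1`, keeps the shared core of compound 1 and changes only one part: 3-(trifluoromethyl)phenyl in place of 4-fluorophenyl on an oxygen on an aromatic ring. Within the data shown here, no measured pair isolates this change, so the step can only be guessed. A small step toward a lower number in this assay is expected, though perhaps not beyond the scatter. Compound 4 is estimated at 250000 nM, between 80000 nM and 800000 nM, which would mean a step of a 2.0-fold lower number from compound 1 to compound 4 (0.29 log units; within the scatter).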

Compound 4, half-maximal inhibitory concentration: 239000 nM
Compound 4: the middle estimate sits 1.0-fold (0.02 log units) above what was measured, and the stated range covers the measured number.
By their numbers in this assay, from the lowest: compound 2; then compounds 3 and 4 (each within the scatter of the next); then compound 1.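

Swapping 4-fluorophenyl for 3-(trifluoromethyl)phenyl on the oxygen gives, in this assay, a 2.1-fold lower number from compound 1 to compound 4 (0.31 log units; beyond the scatter). Among these compounds, this is the first clean one-place comparison here, and it shows that this position accepts the new group with a modest improvement in inhibition. Nothing available explains the step.

The swap alters both the substituent and where it sits on the ring, so these two changes cannot be separated. Going by these compounds, whether a plain phenyl or a chlorophenyl on the same oxygen would give a lower or higher number remains open.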